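Swapping an aryl ring for a sulfonamide on the shared core

This account rests on a few compounds, and the source may have more. Where it says the series, first, only, none or still open, it means among the compounds named here.

Compound 2 `c1ccc(-c2cccc3c2CCC3c2ncc[nH]2)nc1` and compound 1 `Cc1n[nH]cc1-c1cccc2c1CCC2c1ncc[nH]1` share one core and differ only in the group on its aromatic carbon. For the measured compounds named here, in a functional assay on CHO cells for agonist activity at Alpha-1A adrenergic receptor (Homo sapiens), read by FLIPR and calcium flux (on this read-out higher numbers stand for an effect only at larger amounts of compound and lower numbers for an effect already at smaller amounts), compound 1 gives 3 nM, while compound 2 gives 1150 nM, the higher of the two numbers measured so far. Going by the values given here, the single known step, a 380-fold higher number from compound 1 to compound 2 (2.58 log units; beyond the scatter), shows that this position tolerates change poorly. Compound 3 `CCCS(=O)(=O)Nc1cccc2c1CCC2c1ncc[nH]1` carries the change ((propylsulfonyl)amino in place of pyridin-2-yl on an aromatic carbon). Among the compounds with values here, no measured step involves a sulfonamide, so the direction is uncertain; the one step measured only says that the group at this position can shift the number greatly. The number for compound 3 is therefore expected with wide uncertainty, as a step of a 7.7-fold lower number from compound 2 to compound 3 (0.88 log units; beyond the scatter). The estimate for compound 3 in this assay is 150 nM, with a range from 10 nM to 2000 nM.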

Compound 3, half-maximal effective concentration: 1340 nM
Estimate against measurement, compound 3: 8.9-fold (0.95 log units) below, within the range that was stated.
By their numbers in this assay, from the lowest: compound 1; then compounds 2 and 3 (each within the scatter of the next).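

In this assay this change gives a 1.2-fold higher number from compound 2 to compound 3 (0.07 log units; within the scatter), so on this aromatic carbon (propylsulfonyl)amino and pyridin-2-yl cannot be told apart, even though only one of them contains a ring. Measured against 3-methyl-1H-pyrazol-4-yl, the same group gives a 450-fold higher number from compound 1 to compound 3 (2.65 log units; beyond the scatter), so two very different groups now both give numbers far higher than compound 1, whose low number remains the only one of its kind here. Nothing available explains why these two groups match or why compound 1 stands apart.

As far as these compounds go, it stays open whether 1H-pyrazol-4-yl, the same ring without its methyl group, would keep a number close to that of compound 1. Also open, from the compounds shown here alone, is whether an amine or a carboxylic acid on this carbon would fall with compound 1 or with the other two.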